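Swapping a fluorophenyl for a dimethoxyphenyl on a nucleoside

The source may hold more compounds than are shown below. What is called first, only, known or untested is meant among the compounds shown, and "the series" means these compounds.

Compound 1 `OC[C@H]1O[C@@H](n2cnc3c(NCc4ccc(F)cc4)ncnc32)[C@H](O)[C@@H]1O` has the lowest of the two numbers given in a functional assay on HL-60 cells (Homo sapiens) for antiproliferative activity, with a stated time of 72 h (a higher number here means a weaker inhibitor, a lower number a stronger inhibitor), where compound 1 gives 1200 nM. Its nearest neighbour is compound 2 `OC[C@H]1O[C@@H](n2cnc3c(NCc4ccc(Cl)cc4)ncnc32)[C@H](O)[C@@H]1O`, which in this assay gives 1700 nM, and the step of a 1.4-fold higher number from compound 1 to compound 2 (0.15 log units; within the scatter) stays within the scatter. Compound 3 `Cc1ccc(CNc2ncnc3c2ncn3[C@@H]2O[C@H](CO)[C@@H](O)[C@H]2O)cc1` reaches only a limit of the assay in this assay, > 166000 nM (the limit of > 166000 nM in this assay, at which 1 of the 3 values shown sits). The step of an at least 130-fold higher number from compound 1 to compound 3 (2.14 log units; beyond the scatter) is large, as is an at least 97-fold higher number from compound 2 to compound 3 (1.98 log units; beyond the scatter).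

Compound 4 `COc1cccc(CNc2ncnc3c2ncn3[C@@H]2O[C@H](CO)[C@@H](O)[C@H]2O)c1OC` differs from compound 1 by 2,3-dimethoxyphenyl in place of 4-fluorophenyl on a saturated chain carbon bound to a nitrogen on an aromatic ring. Going by the values given here, the measured steps show that chloro in place of fluoro changes little, while methyl in place of fluoro removes measurable activity; no measured step covers a methoxy group or this pattern of substitution, so the expectation rests only on the observation that changing this ring can cost a great deal. Compound 4 is therefore expected to give about 20000 nM in this assay, between 3000 nM and 166000 nM. For compound 4 the expected step is a 17-fold higher number from compound 1 to compound 4 (1.22 log units; beyond the scatter).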

Compound 4, half-maximal inhibitory concentration: > 166000 nM
Compound 4 gave a limit, no number (the forecaster's own chance of this, stated with the estimate: 35%); at least 8.3-fold (0.91 log units) between middle value and limit.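

In this assay compound 4 reaches a limit of the assay, not a number, and compound 3 reaches a limit too: the limit of > 166000 nM in this assay, at which 2 of the 4 values shown sit.

The 2,3-dimethoxyphenyl group in place of 4-fluorophenyl gives an at least 130-fold higher number from compound 1 to compound 4 (2.14 log units; beyond the scatter), and in place of 4-chlorophenyl it gives an at least 97-fold higher number from compound 2 to compound 4 (1.98 log units; beyond the scatter). The large loss at this position is therefore no longer seen with the 4-methylphenyl group alone, and only the 4-fluorophenyl and 4-chlorophenyl groups keep a number; the step from compound 3 to compound 4 cannot be read, since both ends are limits.

Going by these compounds, it remains open whether a single methoxy group on this ring would keep a number in this assay, and whether the loss belongs to the methoxy groups or to their pattern. On these data alone, how a bromo or a trifluoromethyl group would read in place of the fluoro is also open.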